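A longer chain to the (2-aminophenyl)carbamoyl group

The compounds below may be only part of what the source reports. "The series", "measured", "known", "first", "only" and "open" are said of these compounds alone.

Measured so far in an assay on isolated protein for inhibition of protein deacetylase HDAC6 (Homo sapiens), read by fluorescence; on this read-out lower numbers stand for stronger inhibition and higher numbers for weaker inhibition:
Compound 1, `Cn1cc(-c2ccccc2Oc2ccccc2)c2cc(C(=O)NCCCC(=O)NO)[nH]c2c1=O`, gives 144 nM.
Compound 2, `Cn1cc(-c2cc(C(C)(C)O)ccc2Oc2ccc(F)cc2F)c2cc(C(=O)NCc3ccc(C(=O)NO)cc3)[nH]c2c1=O`, gives 15.6 nM.
Compound 3, `Cn1cc(-c2ccccc2Oc2ccccc2)c2cc(C(=O)NCCCCC(=O)Nc3ccccc3N)[nH]c2c1=O`, gives only a limit, > 500 nM.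

Compound 3 thus stands at the weak end of the three compounds, its result being a limit of the assay rather than a number (the limit of > 500 nM in this assay, at which 1 of the 3 values shown sits). Going by the values given here, the one measured step that reaches it, an at least 3.4-fold higher number from compound 1 to compound 3 (0.54 log units; beyond the scatter), shows that exchanging the hydroxycarbamoyl group for the (2-aminophenyl)carbamoyl group weakened inhibition. Compound 4, `Cn1cc(-c2ccccc2Oc2ccccc2)c2cc(C(=O)NCCCCCCC(=O)Nc3ccccc3N)[nH]c2c1=O`, keeps that group and lengthens the chain: 2-((2-aminophenyl)carbamoyl)ethyl in place of (2-aminophenyl)carbamoyl on a saturated chain carbon, four bonds along the chain from an amide-type nitrogen. Among the compounds with values here, no measured step tests chain length on its own, so the change is expected to shift the number little, and the estimated step is a step that the limit leaves unreadable from compound 3 to compound 4. Compound 4 is therefore expected to give about 700 nM, most likely between 150 nM and 3000 nM.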

Compound 4, half-maximal inhibitory concentration: > 500 nM
Compound 4: a limit, no number; the forecaster's own chance of this, stated with the estimate: 55%; the middle value does not contradict the limit.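

Going by these compounds alone, compound 3 and compound 4 both give a limit of the assay rather than a number, so no step between them can be read: the limit of > 500 nM in this assay, at which 2 of the 4 values shown sit. On these data alone, whether the longer chain of compound 4 changes inhibition at all stays open.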